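The source may report more compounds than this note shows. Statements on the series, on what has been measured and on what is new or still open speak of the compounds shown alone.

The three measured compounds in an ADME assay on HepG2 cells (Homo sapiens) for cytotoxicity, with a stated time of 72 h (a higher number here means that more compound is needed for the effect, a lower number that less compound is needed), are:

Compound 1 `Cc1cc(NC(=O)Nc2ccccc2OC(F)(F)F)c2ccccc2n1` gives > 25000 nM, which is a limit of this assay and not a number.
Compound 2 `COc1ccccc1NC(=O)Nc1cc(C)nc2ccccc12` gives > 25000 nM, again a limit rather than a number.
Compound 3 `COc1cccc(NC(=O)Nc2cc(C)nc3ccccc23)c1` gives > 25000 nM, also a limit and not a number.

Compound 4 `Cc1cc(NC(=O)Nc2cccc(OC(F)(F)F)c2)c2ccccc2n1` has not yet been measured. It differs from compound 3 by trifluoromethyl in place of methyl on an oxygen on an aromatic ring. The same change, made from compound 2 to compound 1 (trifluoromethyl in place of methyl on an oxygen on an aromatic ring), produced a step that the two limits leave unreadable from compound 2 to compound 1, so the two limits leave that step unreadable. The difference between the cores of compound 2 and compound 3 is not broken down here. For the measured compounds named here, what can be said about the measured step rests on (the limit of > 25000 nM in this assay, at which 3 of the 3 values shown sit), because the limit of > 25000 nM in this assay, at which 3 of the 3 values shown sit, shows every value so far at the same limit, and no numbered value exists from which a direction could be taken.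

On that basis compound 4 is expected to sit at the limit as well, with an estimated value of 40000 nM and a range from 20000 nM to 120000 nM. The step from compound 3 to compound 4 is expected to be a step that the limit leaves unreadable from compound 3 to compound 4, essentially no readable change.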

Compound 4, half-maximal effective concentration: 13000 nM
Estimate against measurement, compound 4: 3.1-fold (0.49 log units) above; measured number outside the range, below it.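

In this assay, replacing methoxy with trifluoromethoxy gives an at least 1.9-fold lower number from compound 3 to compound 4 (0.28 log units; that floor lies within the scatter), and compound 4 is the only compound shown with a numbered value. Compound 3 gives > 25000 nM, which is a limit of the assay and not a number. The same change from compound 2 to compound 1 cannot be read, so the data show neither that the change carries from one core to the other nor that it fails to, and the series offers little numbered ground for such a comparison: the limit of > 25000 nM in this assay, at which 3 of the 4 values shown sit.

As far as these compounds go, it remains open whether an amine, a carboxylic acid or a longer chain in place of trifluoromethoxy on the shared core of compound 4 would give a numbered value in this assay. From the compounds shown here alone, it also remains open how large the step to compound 4 really is, and whether any group on the core of compound 1 would bring that compound off the limit.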